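This account rests on a few compounds, and the source may have more. Where it says the series, first, only, none or still open, it means among the compounds named here.

Measured so far in an assay on HEK293F cells for inhibition of cholesterol 24-hydroxylase (Homo sapiens), read by trypan blue exclusion, with stated times of 15 min and 5 h; on this read-out higher numbers stand for weaker inhibition and lower numbers for stronger inhibition:
- Compound 1, `CCNC(=O)C1CCN(c2cncnc2-c2ccccc2)CC1`: compound 1 gives 58 nM
- Compound 2, `CN(C)C(=O)C1CCN(c2cncnc2-c2ccccc2)CC1`: compound 2 gives 16 nM

Among the compounds with values here, compound 2 holds the lowest of the two numbers in this assay; its only neighbour is compound 1, and the one measured step, a 3.6-fold lower number from compound 1 to compound 2 (0.56 log units; beyond the scatter), separates them.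

Compound 3, `CN(C)C(=O)C1CCN(c2cncnc2-c2ccc(F)cc2)CC1`, differs from compound 2 by fluoro in place of hydrogen on an aromatic carbon. Within the data shown here, no measured step touches the phenyl ring: the only step known, a 3.6-fold lower number from compound 1 to compound 2 (0.56 log units; beyond the scatter), concerns the amide substituent and so gives no guide to this change. With nothing in the measured pairs bearing on it, the expectation for compound 3 is a step of a 1.1-fold lower number from compound 2 to compound 3 (0.06 log units; within the scatter), that is, no change beyond the scatter, in either direction. On that basis compound 3 is estimated at 14 nM in this assay, with a range from 6 nM to 35 nM.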

Compound 3, half-maximal inhibitory concentration: 7.3 nM
For compound 3 the middle estimate is 1.9-fold (0.28 log units) above the measured one; the measured number falls inside the stated range.
By their numbers in this assay, from the lowest: compound 3; then compound 2; then compound 1.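

The earlier compounds shown here spoke only to the amide substituent, whereas compound 3 shows that the phenyl ring is also a place where a single change moves the number in this assay. Going from phenyl to 4-fluorophenyl gives a 2.2-fold lower number from compound 2 to compound 3 (0.34 log units; beyond the scatter), so one fluoro on an aromatic carbon, para to a large group, is enough to shift the read-out beyond the scatter and toward stronger inhibition. Nothing available here accounts for why this change has this result.

The compounds shown leave open whether chloro, methoxy or a nitrile in that place would go the same way, and whether fluoro on another carbon of the ring would do so. They also leave open how 4-fluorophenyl behaves with the ethylamino amide of compound 1, as here it appears only with the dimethylamino amide.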